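This account rests on a few compounds, and the source may have more. Where it says the series, first, only, none or still open, it means among the compounds named here.

Measured compounds: compound 1 `CO/N=C/c1c(N)ncnc1Oc1ccc2[nH]ccc2c1` gives 3520 nM in a functional assay on HCT-116 cells (Homo sapiens) for antiproliferative activity; on this read-out lower numbers stand for stronger inhibition and higher numbers for weaker inhibition; compound 2 `COCCCO/N=C/c1c(N)ncnc1Oc1ccc2[nH]c(C)cc2c1F` gives 438 nM; compound 3 `CO/N=C/c1c(N)ncnc1Oc1ccc2[nH]cc(C)c2c1` gives 385 nM.

Compound 2 stands second highest of the three numbers, within the scatter of compound 3 and well apart from compound 1. Compound 4 `C=CCO/N=C/c1c(N)ncnc1Oc1ccc2[nH]c(C)cc2c1F` differs from compound 2 by vinyl in place of 2-methoxyethyl on a saturated chain carbon bound to an oxygen on an unsaturated carbon. Going by the values given here, no measured step touches this part of the molecule: the only step known, a 9.1-fold lower number from compound 1 to compound 3 (0.96 log units; beyond the scatter), concerns a methyl on an aromatic carbon elsewhere on the shared core, so it says nothing about the chain on the oxygen. Without a precedent, compound 4 is expected to land close to compound 2, with a step of a 1.1-fold higher number from compound 2 to compound 4 (0.06 log units; within the scatter). The estimate for compound 4 is 500 nM, within 200 nM to 1300 nM.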

Compound 4, half-maximal inhibitory concentration: 40 nM
Estimate against measurement, compound 4: 13-fold (1.10 log units) above; measured number below the stated range.
By their numbers in this assay, from the lowest: compound 4; then compounds 3 and 2 (each within the scatter of the next); then compound 1.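

Going by these compounds alone, the chain on the oxygen matters strongly in this assay: replacing 3-methoxypropyl with allyl gives an 11-fold lower number from compound 2 to compound 4 (1.04 log units; beyond the scatter) and is the first measured change at this position. Within the data shown here, the only earlier step, a 9.1-fold lower number from compound 1 to compound 3 (0.96 log units; beyond the scatter), concerned a methyl on an aromatic carbon elsewhere on the shared core. No measurement at hand bears on why the number falls.

This single pair leaves open whether the double bond of allyl or the loss of the chain's oxygen matters more. A propyl chain or a chain ending in an amine could help separate these possibilities.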